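Fluoro to Methyl Swap, Second Occurrence in the Series

The source may hold more compounds than are shown below. What is called first, only, known or untested is meant among the compounds shown, and "the series" means these compounds.

Of the compounds shown here, three have been measured in a functional assay with Homo sapiens as the target; a higher number here means a weaker inhibitor, a lower number a stronger inhibitor. Compound 1 `Cc1c(C(=O)Nc2cccc(F)c2)cnn1-c1ccc(F)cc1` gives 3000 nM. Compound 2 `Cc1cccc(NC(=O)c2cnn(-c3ccc(F)cc3)c2C)c1` gives 5700 nM. Compound 3 `Cc1c(C(=O)Nc2ccc(C(F)(F)F)cc2)cnn1-c1cccc(F)c1` gives 3100 nM. The values of compound 1 and compound 3 lie within the scatter of each other, as do those of compound 3 and compound 2, so no order among the three is claimed.

Compound 1 and compound 2 differ in one place only: methyl in place of fluoro on an aromatic carbon. This change gave a 1.9-fold higher number from compound 1 to compound 2 (0.28 log units; within the scatter), a step within the scatter.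

The same change now goes from compound 3 to compound 4 `Cc1cccc(-n2ncc(C(=O)Nc3ccc(C(F)(F)F)cc3)c2C)c1`, which is not yet measured: methyl in place of fluoro on an aromatic carbon. The place lines of the two changes agree word for word, so this is the same change made on two cores. How the core of compound 3 differs from the core of compound 1 is not broken down here; the two differ in more than one place.

Among the compounds shown the change occurs in two pairs, one measured, one pending. Going by the values given here, with only one measured instance, the expectation for compound 4 rests on that single step. The step expected here is a 1.8-fold higher number from compound 3 to compound 4 (0.25 log units; within the scatter), resting on a 1.9-fold higher number from compound 1 to compound 2 (0.28 log units; within the scatter) and on compound 3 giving 3100 nM. Compound 4 is expected at 5500 nM, with a range from 2500 nM to 12000 nM. Among the compounds with values here, the range is wide; only one prior step is available.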

Compound 4, half-maximal inhibitory concentration: 2500 nM
Compound 4: the middle estimate sits 2.2-fold (0.34 log units) above what was measured; low and high end bracket the measured number.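

In this assay, the change from 3-fluorophenyl to 3-methylphenyl gives a 1.2-fold lower number from compound 3 to compound 4 (0.09 log units; within the scatter), so on this core the step again stays inside the scatter. Set beside the earlier step, the new one cannot be told apart from it: the same change on two cores in this assay, a 1.9-fold higher number (0.28 log units; within the scatter) from compound 1 to compound 2 and a 1.2-fold lower number (0.09 log units; within the scatter) from compound 3 to compound 4, 2.4-fold (0.37 log units) apart, within the scatter of two such steps. Going by these compounds alone, this shows that, on these two cores, methyl in place of fluoro on an aromatic carbon has so far produced no step that stands clear of the scatter, and the opposite directions of the two steps carry no weight; it does not show that the change is without effect in general, that it would stay this small on other cores, or that the two cores respond identically, as two pairs of this kind are too few to settle those points.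

The compounds shown leave open whether any replacement on this aromatic carbon moves the number beyond the scatter, for instance a chloro group, a methoxy group, an amine or a carboxylic acid in place of the fluoro. Also open, from the compounds shown here alone, is how the fluoro to methyl change reads on a further core, such as one with a nitrile in place of the trifluoromethyl of compound 4.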